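Thiophen-2-yl for 1H-pyrazol-4-yl: a flat step expected

A few compounds are considered here, and "the series" means these few. Any claim that something is new, unique, unknown or untested is made for them only; others in the source may bear on it.

Of the compounds shown here, three sharing one core have been measured in an assay on CHO cells for displacement of a labelled ligand from adenosine receptor A1 (Homo sapiens), read by scintillation counting, tested at 10 uM; a higher number here means more inhibition at the concentration tested (going by the name of the read-out), a lower number less inhibition. Compound 1 `CC(C)(C)Cc1c(-c2ccc(F)cc2)sc(N)c1C(=O)c1ccc(Cl)cc1` gives 1%. Compound 2 `CC(C)(C)Cc1c(-c2ccc(Cl)cc2)sc(N)c1C(=O)c1ccc(Cl)cc1` gives 1% in this assay, and compound 3 `CC(C)(C)Cc1c(-c2cn[nH]c2)sc(N)c1C(=O)c1ccc(Cl)cc1` gives 1%. Compound 3 thus stands level with compounds 1 and 2 at the digits shown, with compound 1 nearest and compound 2 furthest, both within the scatter. The measured steps agree: no change at the digits printed from compound 1 to compound 2 (within the scatter), no change at the digits printed from compound 1 to compound 3 (within the scatter), and no change at the digits printed from compound 2 to compound 3 (within the scatter). Every exchange of the group on this aromatic carbon has left the read-out where it was.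

Compound 4 `CC(C)(C)Cc1c(-c2cccs2)sc(N)c1C(=O)c1ccc(Cl)cc1` has not yet been measured. It differs from compound 3 in one place: thiophen-2-yl in place of 1H-pyrazol-4-yl on an aromatic carbon. Going by the values given here, the steps that bear on this change are the two that also swap the group at this carbon, from compound 1 to compound 3 and from compound 2 to compound 3, both within the scatter, so no step beyond the scatter is expected here either. Compound 4 is therefore expected to give 1%, within -8% to 12% in this assay. This amounts to an expected step of no change at the digits printed from compound 3 to compound 4 (within the scatter).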

Compound 4, a percentage reported as inhibition, at one concentration (the size of the read-out at that concentration, not a potency): 1%
The estimate for compound 4 equals the measured number at the digits printed; the range from low to high includes it.
By their numbers in this assay, from the lowest: compounds 1, 2, 3 and 4 (each within the scatter of the next).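

Exchanging a ring that has a hydrogen-bond donor for one that has none, with sulfur as its only hetero atom, makes no visible difference in this assay (no change at the digits printed from compound 3 to compound 4 (within the scatter)). The same holds when thiophen-2-yl replaces either halogenated phenyl group (no change at the digits printed from compound 2 to compound 4 (within the scatter); no change at the digits printed from compound 1 to compound 4 (within the scatter)), so this aromatic carbon, next to the ring sulfur, has now carried two five-membered aromatic rings and two substituted phenyl groups with no step beyond the scatter. No available evidence accounts for this flat result.

On these data alone, whether an open-chain amine or a carboxylic acid on this carbon would move the reading remains open. So does whether a shorter chain in place of the neopentyl group would do so, since all four compounds share that group.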